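Thiazole sulfide and sulfone oxime ethers: rat in vivo notes

The compounds below may be only part of what the source reports. "The series", "measured", "known", "first", "only" and "open" are said of these compounds alone.

Compound 1 `CO[C@]1(c2cnc(Sc3ccc(/C(C)=N/O)cc3)s2)CCO[C@@H](C)C1` carries the free oxime and a sulfide link. In a functional assay on the whole organism with Rattus norvegicus as the target, with a stated time of 3 h (on this read-out lower numbers stand for an effect already at smaller amounts and higher numbers for an effect only at larger amounts of compound), compound 1 gives 0.3 mg/kg. Compound 2 `CO[C@]1(c2cnc(S(=O)(=O)c3ccc(/C(C)=N/O)cc3)s2)CCO[C@@H](C)C1` is the corresponding sulfone; in this assay compound 2 gives 1 mg/kg. The difference between the two cores is not broken down here. Compound 3 `CO[C@]1(c2cnc(S(=O)(=O)c3ccc(/C(C)=N/OCC#N)cc3)s2)CCO[C@@H](C)C1` adds the cyanomethyl on the oxime oxygen of compound 2; in this assay compound 3 gives 0.5 mg/kg. The change from compound 2 to compound 3 is cyanomethyl in place of hydrogen on an oxygen and it made a 2.0-fold lower number from compound 2 to compound 3 (0.30 log units; within the scatter). Compound 1 sits at the lowest number of the three, within the scatter of compound 3 and beyond it only against compound 2.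

Compound 4 `CO[C@]1(c2cnc(Sc3ccc(/C(C)=N/OCC#N)cc3)s2)CCO[C@@H](C)C1` is not yet measured in this assay. Relative to compound 1 it shows (cyanomethyl in place of hydrogen on an oxygen), the same change as that between compound 2 and compound 3, placed on an oxygen with the same surroundings. Among the measured compounds shown here, because a 2.0-fold lower number from compound 2 to compound 3 (0.30 log units; within the scatter) stayed within the scatter, the expected step for compound 4 is a 1.5-fold lower number from compound 1 to compound 4 (0.18 log units; within the scatter), a modest move in the same direction, with no further pairs to support a larger shift. On this basis compound 4 is expected to give 0.2 mg/kg in this assay, with a likely range from 0.08 mg/kg to 0.5 mg/kg.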

Compound 4, dose for half-maximal effect: 0.3 mg/kg
The estimate for compound 4 lay 1.5-fold (0.18 log units) below the measured number; measured number inside the range.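

On the sulfide core, cyanomethyl in place of hydrogen on an oxygen gave no change at the digits printed from compound 1 to compound 4 (within the scatter) in this assay, so the lower number seen on the sulfone core did not reappear at the digits printed. Set side by side, the two results for this change do not separate on the two cores: the same change on two cores in this assay, a 2.0-fold lower number (0.30 log units; within the scatter) from compound 2 to compound 3 and no change at the digits printed (within the scatter) from compound 1 to compound 4, 2.0-fold (0.30 log units) apart, within the scatter of two such steps. This fits a change that carries from one core to the other without a step that can be told from the scatter, but each step lies within the scatter on its own, so the two pairs show neither a real effect of cyanomethyl on either core nor a real dependence on the core, and two pairs in a single whole-animal read-out are too few to set a transfer rule for the series.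

The compounds shown leave open whether any other group on this oxygen, such as a plain methyl, a longer chain ending in a nitrile, a carboxylic acid or an amine, would give a step beyond the scatter. They also leave open whether cyanomethyl in place of hydrogen behaves the same way on any core other than these two.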